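Swapping the indole nitrogen substituent in a cytotoxicity series

A few compounds are considered here, and "the series" means these few. Any claim that something is new, unique, unknown or untested is made for them only; others in the source may bear on it.

Measured compounds:
compound 1, `O=C1COCCN1c1ccc(/N=C\c2c[nH]c3ccccc23)cc1`, 105%
compound 2, `O=C1COCCN1c1ccc(/N=C\c2cn(C(=O)c3ccc(Cl)cc3)c3ccccc23)cc1`, 97.6%

In an ADME assay on BV-2 cells (Mus musculus) for cytotoxicity, read by MTT assay, with a stated time of 48 h, tested at 1 uM (a higher number here means a weaker effect of the compound at the concentration tested, a lower number a stronger effect), compound 2 gives the lowest of the two numbers, but its nearest neighbour is compound 1, and the two sit within the scatter of each other. Going by the values given here, the single measured step, a number 7.4 percentage points lower from compound 1 to compound 2 (within the scatter), puts a (4-chlorophenyl)carbonyl on the aromatic nitrogen without a change beyond the scatter.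

Compound 3, `O=C1COCCN1c1ccc(/N=C\c2cn(Cc3ccc(F)cc3)c3ccccc23)cc1`, has not yet been measured. It differs from compound 2 by 4-fluorobenzyl in place of (4-chlorophenyl)carbonyl on an aromatic nitrogen. Among the compounds with values here, no measured step exchanges one group for another at this nitrogen; the only step that touches this position, from compound 1 to compound 2, stayed within the scatter. On that basis no step beyond the scatter is expected, and a number 0.4 percentage points higher from compound 2 to compound 3 (within the scatter) is the estimated change. Compound 3 is therefore expected to give about 98%, within a range of 85% to 110%.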

Compound 3, a percentage reported as activity, at one concentration (the size of the read-out at that concentration, not a potency): 87.9%
Compound 3: the middle estimate sits 10.1 percentage points above what was measured, within the range that was stated.
By their numbers in this assay, from the lowest: compounds 3, 2 and 1 (each within the scatter of the next, the first and the last beyond it).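

Exchanging (4-chlorophenyl)carbonyl for 4-fluorobenzyl on the aromatic nitrogen in this assay gives a number 9.7 percentage points lower from compound 2 to compound 3 (within the scatter) and so does not separate the two substituted compounds. Going by these compounds alone, measured against hydrogen on that nitrogen, however, 4-fluorobenzyl gives a number 17.1 percentage points lower from compound 1 to compound 3 (beyond the scatter) and is the first group at this position to produce a step beyond the scatter, which (4-chlorophenyl)carbonyl did not do. No available evidence bears on why this step arises.

As far as these compounds go, whether the step belongs to the benzyl part of the group or to its fluorine remains open, as does what a plain benzyl, a short alkyl chain or a chain ending in an amine would give on this nitrogen. From the compounds shown here alone, the read-out comes from a single concentration, so the effect at higher concentrations also remains open.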